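The compounds below may be only part of what the source reports. "The series", "measured", "known", "first", "only" and "open" are said of these compounds alone.

Values in a functional assay on QGY-7703 cells (Homo sapiens) for cytotoxicity, read by MTT assay, with a stated time of 24 h (a lower number here means a stronger inhibitor, a higher number a weaker inhibitor), so far:
- compound 1 `O=C1/C(=C/c2cccnc2)CN(S(=O)(=O)c2ccc(Cl)cc2)C/C1=C\c1ccccc1F` gives 12100 nM
- compound 2 `O=C1/C(=C/c2cccnc2)CN(S(=O)(=O)c2ccc([N+](=O)[O-])cc2)C/C1=C\c1ccccc1C(F)(F)F` gives 7660 nM
- compound 3 `O=C1/C(=C/c2cccnc2)CN(S(=O)(=O)c2ccc(C(F)(F)F)cc2)C/C1=C\c1ccccc1C(F)(F)F` gives 1500 nM

Compound 3 has the lowest of these three numbers. Compound 4 `O=C1/C(=C/c2cccnc2)CN(S(=O)(=O)c2ccc(Cl)cc2)C/C1=C\c1ccccc1C(F)(F)F` is next, and the change is chloro in place of trifluoromethyl on an aromatic carbon. For the measured compounds named here, the only measured step at this place is a 5.1-fold lower number from compound 2 to compound 3 (0.71 log units; beyond the scatter), a modest one in which trifluoromethyl replaced nitro. Compound 1 also carries chloro there but differs elsewhere, so it is only a loose guide. Losing trifluoromethyl is therefore expected to raise the number modestly, and the estimated change is a 2.3-fold higher number from compound 3 to compound 4 (0.37 log units; beyond the scatter). For compound 4 the estimate is 3500 nM, with an expected range from 1500 nM to 8500 nM.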

Compound 4, half-maximal inhibitory concentration: 3440 nM
Estimate against measurement, compound 4: 1.0-fold (0.01 log units) above; the measured number falls inside the stated range.
By their numbers in this assay, from the lowest: compound 3; then compound 4; then compounds 2 and 1 (each within the scatter of the next).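

In this assay, chloro adds a third substituent at this place, on the aromatic carbon para to a large group: the series shows (a 2.3-fold higher number from compound 3 to compound 4 (0.36 log units; beyond the scatter)) and (a 2.2-fold lower number from compound 2 to compound 4 (0.35 log units; beyond the scatter)), so the numbers rise from trifluoromethyl to chloro to nitro in these three compounds. Compound 4 also isolates the other aromatic substituent with chloro held fixed, with trifluoromethyl in place of fluoro (a 3.5-fold lower number from compound 1 to compound 4 (0.55 log units; beyond the scatter)). No measurement at hand explains these steps.

From the compounds shown here alone, whether an amine or a carboxylic acid at this place would fit that order remains open. So does whether the order holds when fluoro replaces trifluoromethyl on the other aromatic ring.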